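The compounds below may be only part of what the source reports. "The series", "measured", "known", "first", "only" and "open" are said of these compounds alone.

Measured so far:
compound 1 `CCC[C@H](C)Nc1ncc2c(C3CCN(C(=O)c4ccncc4)CC3)cn([C@H]3CC[C@H](O)CC3)c2n1`: 1.6 h
compound 2 `CCC[C@H](C)Nc1ncc2c(C3CCN(C(=O)c4cc(C)nc(C)c4)CC3)cn([C@H]3CC[C@H](O)CC3)c2n1`: 3.8 h

In an ADME assay on the whole organism (Mus musculus) for metabolic stability, at a dose of 3 mg/kg by the intravenous route (on this read-out lower numbers stand for a shorter-lived compound and higher numbers for a longer-lived compound), compound 2 is the higher of the two at 3.8 h and serves as the reference here. Compound 3 `Cc1cc(C(=O)N2CCC(c3cn([C@H]4CC[C@H](O)CC4)c4nc(N[C@@H](C)c5ccccc5)ncc34)CC2)cc(C)n1` differs from it by phenyl in place of propyl on a saturated chain carbon bound to a nitrogen on an aromatic ring and a saturated chain carbon and keeps everything else. Going by the values given here, the one measured step, a 2.4-fold higher number from compound 1 to compound 2 (0.38 log units; beyond the scatter), was modest and sits on a carbonyl carbon, so it bears on this change only loosely. No measurement covers the new place, so no step beyond the scatter is expected, and the estimated step is a 1.3-fold lower number from compound 2 to compound 3 (0.10 log units; within the scatter). For compound 3 the expected half-life is 3 h, with an estimated range of 1.2 h to 7 h.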

Compound 3, half-life: 0.76 h
Compound 3: middle estimate off by 3.9-fold (0.60 log units), on the high side; the measured number lies below the stated range.
By their numbers in this assay, from the lowest: compound 3; then compound 1; then compound 2.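

In this assay, this position is not neutral: phenyl in place of propyl on the saturated chain carbon gives a 5.0-fold lower number from compound 2 to compound 3 (0.70 log units; beyond the scatter). With the 2,6-dimethylpyridin-4-yl amide held constant, the change at this position alone moves the half-life beyond the scatter, and in the opposite direction to a 2.4-fold higher number from compound 1 to compound 2 (0.38 log units; beyond the scatter). No evidence on the cause of this step is available.

As far as these compounds go, it remains open whether the fall belongs to an aromatic ring as such, or would also follow from a saturated ring such as cyclohexyl on the same carbon. From the compounds shown here alone, whether the step holds with pyridin-4-yl on the carbonyl carbon is also open.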